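A few compounds are considered here, and "the series" means these few. Any claim that something is new, unique, unknown or untested is made for them only; others in the source may bear on it.

Measured so far in a functional assay on DU-145 cells (Homo sapiens) for cytotoxicity, read by trypan blue exclusion, with a stated time of 96 h; on this read-out lower numbers stand for stronger inhibition and higher numbers for weaker inhibition:
- compound 1 `COc1cc(OC)c(/C=C/S(=O)(=O)Nc2ccc(OC)c(F)c2)c(OC)c1` gives 200 nM
- compound 2 `COC(=O)C(C)Nc1cc(NS(=O)(=O)/C=C/c2c(OC)cc(OC)cc2OC)ccc1OC` gives 100 nM
- compound 3 `COC(=O)C(Nc1cc(NS(=O)(=O)/C=C/c2c(OC)cc(OC)cc2OC)ccc1OC)c1ccc(F)cc1` gives 2500 nM

Compound 3 (2500 nM) holds the highest of the three numbers, beyond the scatter from both others. Next comes compound 4 `COc1cc(OC)c(/C=C/S(=O)(=O)Nc2ccc(OC)c(NC(C)(C)C(=O)O)c2)c(OC)c1` with 1-carboxy-1-methylethyl in place of (4-fluorophenyl)(methoxycarbonyl)methyl on a nitrogen on an aromatic ring. For the measured compounds named here, two measured steps bear on this change. The larger is a 25-fold higher number from compound 2 to compound 3 (1.40 log units; beyond the scatter) and came with 4-fluorophenyl in place of methyl, a group that compound 4 no longer carries. The other is a 2.0-fold lower number from compound 1 to compound 2 (0.30 log units; within the scatter) and came with (1-(methoxycarbonyl)ethyl)amino in place of fluoro. Going by the values given here, no measured compound carries the carboxy group, so that part of the change is untested, and a full return to the number of compound 2 is not assumed. A lower number is expected in this assay and the estimated size is an 8.3-fold lower number from compound 3 to compound 4 (0.92 log units; beyond the scatter) in this direction. For compound 4 the estimate is 300 nM with an expected range of 60 nM to 1500 nM as the outcome.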

Compound 4, half-maximal inhibitory concentration: 70 nM
Estimate against measurement, compound 4: 4.3-fold (0.63 log units) above; measured number inside the range.
By their numbers in this assay, from the lowest: compounds 4, 2 and 1 (each within the scatter of the next, the first and the last beyond it); then compound 3.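

In this assay, a low number on this nitrogen is recovered with the 4-fluorophenyl gone: a 36-fold lower number from compound 3 to compound 4 (1.55 log units; beyond the scatter), with 1-carboxy-1-methylethyl in place of (4-fluorophenyl)(methoxycarbonyl)methyl. Carboxy and ester chains are not told apart at this position, as a 1.4-fold lower number from compound 2 to compound 4 (0.15 log units; within the scatter) stays within the scatter. Replacing fluoro with (1-carboxy-1-methylethyl)amino gives a 2.9-fold lower number from compound 1 to compound 4 (0.46 log units; beyond the scatter), which is beyond the scatter, whereas the step to the ester-bearing compound 2 was within it, and compound 3 shows that a substituted amino group does not by itself guarantee a low number.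

Still open, on these data alone, is how the carboxy group and the methyl groups each contribute, and whether an amide or a longer chain on this nitrogen would hold these numbers. No evidence at hand explains any of these steps.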